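The source may hold more compounds than are shown below. What is called first, only, known or untested is meant among the compounds shown, and "the series" means these compounds.

Measured compounds in a functional assay on cells for positive allosteric modulation of metabotropic glutamate receptor 2 (Homo sapiens), read by fluorescence and calcium flux, with a stated time of 30 min; on this read-out lower numbers stand for an effect already at smaller amounts and higher numbers for an effect only at larger amounts of compound: compound 1 `Fc1cc(Cl)ccc1-c1ccc(Cn2nnc3ccccc32)cc1` gives 28 nM; compound 2 `Clc1ccc(-c2ccc(Cn3nnc4ccccc43)cc2)c(Cl)c1` gives 79 nM; compound 3 `Clc1cc(Br)c2nnn(CC3CC3)c2c1` gives 60 nM.

Compound 1 and compound 2 share a core and differ only by fluoro in place of chloro on an aromatic carbon, a change that brought a 2.8-fold lower number from compound 2 to compound 1 (0.45 log units; beyond the scatter). Compound 3 rests on a different core, and the difference between the two cores is not broken down here. The unmeasured compound 4 `Fc1cc(Br)c2nnn(CC3CC3)c2c1` is related to compound 3 by fluoro in place of chloro on an aromatic carbon, the same kind of change, but in a different setting: here the place is part of a fused or bridged system of two rings, meta to a bromo group, meta to a fused ring and para to a fused ring, whereas in compound 2 it is ortho to a large group and meta to a chloro group. Because a 2.8-fold lower number from compound 2 to compound 1 (0.45 log units; beyond the scatter) was only a modest step, and the surroundings differ, a somewhat smaller step is expected here, a 1.7-fold lower number from compound 3 to compound 4 (0.23 log units; within the scatter). Compound 4 is accordingly estimated at 35 nM, expected to fall between 15 nM and 90 nM.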

Compound 4, half-maximal effective concentration: 70 nM
Compound 4: the middle estimate sits 2.0-fold (0.30 log units) below what was measured; the measured number falls inside the stated range.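

Fluoro in place of chloro on an aromatic carbon brought a 1.2-fold higher number from compound 3 to compound 4 (0.07 log units; within the scatter) in this assay. The lower number seen with this change on the core of compound 1 therefore did not carry over to the core of compound 3, and the two steps differ: the same change on two cores in this assay, a 2.8-fold lower number (0.45 log units; beyond the scatter) from compound 2 to compound 1 and a 1.2-fold higher number (0.07 log units; within the scatter) from compound 3 to compound 4, 3.3-fold (0.52 log units) apart, beyond the scatter of two such steps

This shows that the step cannot simply be transferred between these two cores, but two pairs do not show what sets the difference or how the change would behave on a further core. The compounds shown leave open how a methyl, a methoxy or a nitrile would fare at the same place on either core. They also leave open what an amine or a carboxylic acid elsewhere on these cores would do.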